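A few compounds are considered here, and "the series" means these few. Any claim that something is new, unique, unknown or untested is made for them only; others in the source may bear on it.

In a functional assay on SK-MEL-28 cells (Homo sapiens) for inhibition, read by MTT assay, with a stated time of 72 h (a higher number here means a weaker inhibitor of growth, a lower number a stronger inhibitor of growth), the two measured compounds are:

Compound 1, `COC(=O)/C=C/C1=CC[C@H]2C(C)(C)CCC[C@]2(C)[C@H]1C=O`: 27000 nM
Compound 2, `CC1(C)CCC[C@]2(C)[C@@H](C=O)C(/C=C/C#N)=CC[C@@H]12`: 42000 nM

Within the data shown here, compound 1 is one of only two compounds measured, and its number cannot be told apart from that of compound 2: a 1.6-fold higher number from compound 1 to compound 2 (0.19 log units; within the scatter). That single step swaps a cyano for a methoxycarbonyl and says nothing about the ester chain itself.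

Compound 3, `C#CCCCOC(=O)/C=C/C1=CC[C@H]2C(C)(C)CCC[C@]2(C)[C@H]1C=O`, keeps the whole core of compound 1 and changes only the ester: but-3-yn-1-yl in place of hydrogen on a saturated chain carbon bound to an oxygen next to a carbonyl group, that is, methoxycarbonyl becomes ((pent-4-yn-1-yl)oxy)carbonyl. Among the measured compounds shown here, no measured step touches this part of the molecule, so nothing among the measured compounds points to a shift in either direction. The plain expectation is therefore a number close to that of compound 1, with the step of a 1.1-fold lower number from compound 1 to compound 3 (0.03 log units; within the scatter) expected to stay within the scatter. Compound 3 is estimated at 25000 nM, within a range of 8000 nM to 80000 nM.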

Compound 3, concentration for 50% growth inhibition: 36000 nM
For compound 3 the middle estimate is 1.4-fold (0.16 log units) below the measured one; measured number inside the range.
By their numbers in this assay, from the lowest: compounds 1, 3 and 2 (each within the scatter of the next).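

In this assay, replacing methoxycarbonyl with ((pent-4-yn-1-yl)oxy)carbonyl places but-3-yn-1-yl, with its triple bond, on a saturated chain carbon bound to an oxygen next to a carbonyl group, and the result is a 1.3-fold higher number from compound 1 to compound 3 (0.12 log units; within the scatter), so the two numbers cannot be told apart. Among these compounds, this is the first sign that the ester chain can be made longer and end in a triple bond without a readable shift in the number. The swap of cyano for this longer ester gives the same picture, with a 1.2-fold lower number from compound 2 to compound 3 (0.07 log units; within the scatter), and nothing measured here offers an explanation for these results.

Going by these compounds, whether an amine or a carboxylic acid at the end of the chain, or a much longer chain, would shift the number remains open. The compounds shown also leave open whether any change to the shared core would move the number beyond the scatter.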